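Swapping a Methoxy Tail for a Trifluoroethyl Tail

The compounds below may be only part of what the source reports. "The series", "measured", "known", "first", "only" and "open" are said of these compounds alone.

Compound 1, `Cc1nc(NC(C)(C)C)nc(N[C@@H]2C[C@H](CO)[C@@H](O)[C@H]2O)c1-c1nc2ccccc2s1`: 2220 ng.h/mL
Compound 2, `COCCNc1nc(C)c(-c2nc3ccccc3s2)c(N[C@@H]2C[C@H](CO)[C@@H](O)[C@H]2O)n1`: 2630 ng.h/mL

Both compounds share one core and differ only in the group carried on a nitrogen on an aromatic ring. In an ADME assay on the whole organism (plasma) for pharmacokinetics, with Rattus norvegicus as the target, with a stated time of 6 h, at a dose of 10 mg/kg by the oral route (on this read-out higher numbers stand for higher exposure at the dose given and lower numbers for lower exposure), compound 2 gives 2630 ng.h/mL, the higher of the two numbers measured, but the step of a 1.2-fold higher number from compound 1 to compound 2 (0.07 log units; within the scatter) is small enough that the two compounds cannot be told apart on this read-out.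

Compound 3, `Cc1nc(NCCCC(F)(F)F)nc(N[C@@H]2C[C@H](CO)[C@@H](O)[C@H]2O)c1-c1nc2ccccc2s1`, keeps the same core and changes only the end of that side chain: 2,2,2-trifluoroethyl in place of methoxy on a saturated chain carbon, two bonds along the chain from a nitrogen on an aromatic ring.

Within the data shown here, only one measured step bears on this change, the one from the tert-butyl compound to the methoxyethyl compound, and it stayed within the scatter. With a single comparison, and one that showed no shift, there is no basis for expecting compound 3 to move far in either direction in this assay. The step of a 1.1-fold lower number from compound 2 to compound 3 (0.04 log units; within the scatter) is therefore expected to stay inside the usual scatter. Compound 3 is estimated to give 2400 ng.h/mL, with a likely range from 1000 ng.h/mL to 6000 ng.h/mL.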

Compound 3, area under the concentration-time curve: 1040 ng.h/mL
Compound 3: middle estimate off by 2.3-fold (0.36 log units), on the high side; the range from low to high includes it.
By their numbers in this assay, from the lowest: compound 3; then compounds 1 and 2 (each within the scatter of the next).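

In this assay, among these compounds, the end of this side chain proves able to shift the number: 2,2,2-trifluoroethyl in place of methoxy gives a 2.5-fold lower number from compound 2 to compound 3 (0.40 log units; beyond the scatter) and is the first step in this set to lie beyond the scatter, though its size is only modest. Compared with the tert-butyl group, the 4,4,4-trifluorobutyl chain gives a 2.1-fold lower number from compound 1 to compound 3 (0.33 log units; beyond the scatter) and this step is also modest and beyond the scatter, which leaves compound 3 lowest of the three, while compound 1 and compound 2 remain within the scatter of each other. No measurement shown here offers a cause for the lower number in compound 3.

Compound 3 differs from compound 2 both in carrying fluorine and in losing the oxygen of the methoxy group, so these two features cannot be separated, and a plain butyl chain with no fluorine on the same nitrogen would help to pull them apart. An amine or a carboxylic acid at the end of this chain would show whether other end groups also move the number, and in which direction.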